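This account rests on a few compounds, and the source may have more. Where it says the series, first, only, none or still open, it means among the compounds named here.

Compound 1 `Cc1n[nH]c2ccc(-c3nc4cnc(N5CCN(C)CC5)cn4c3Nc3ccc(Cl)cc3)cc12` and compound 2 `Cc1n[nH]c2ccc(-c3nc4cnc(N5CCN(C)CC5)cn4c3Nc3ccc(Br)cc3)cc12` share a core and differ only by bromo in place of chloro on an aromatic carbon. In a functional assay on MV4-11 cells (Homo sapiens) for inhibition, with a stated time of 120 h, tested at 10 uM (on this read-out lower numbers stand for less inhibition and higher numbers for more inhibition at the one concentration tested (going by the name of the read-out)), compound 1 gives 83.7% and compound 2 gives 83%; the step of a number 0.7 percentage points lower from compound 1 to compound 2 (within the scatter) is within the scatter, so compound 2 stands level with compound 1 in this assay. Compound 3 `Cc1n[nH]c2ccc(-c3nc4cnc(N5CCN(C)CC5)cn4c3Nc3ccc(Br)cc3Cl)cc12` carries the change (chloro in place of hydrogen on an aromatic carbon). For the measured compounds named here, no measured step adds a group to this ring, so the expected step of a number 3 percentage points lower from compound 2 to compound 3 (within the scatter) is small, without a direction beyond the scatter. Compound 3 is estimated at 80%, between 60% and 92%.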

Compound 3, a percentage reported as inhibition, at one concentration (the size of the read-out at that concentration, not a potency): 70.5%
The estimate for compound 3 lay 9.5 percentage points above the measured number; the range from low to high includes it.
By their numbers in this assay, from the lowest: compound 3; then compounds 2 and 1 (each within the scatter of the next).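

In this assay, the addition of chloro ortho to a large group, on a ring where bromo in place of chloro had left the read-out within the scatter, gives a number 12.5 percentage points lower from compound 2 to compound 3 (beyond the scatter). The change from 4-chlorophenyl to 4-bromo-2-chlorophenyl points the same way, with a number 13.2 percentage points lower from compound 1 to compound 3 (beyond the scatter). So this position responds to substitution, at least with chloro on the 4-bromophenyl group. Nothing available bears on the reason for this step.

As far as these compounds go, it remains open whether the step is specific to chloro: a fluoro, methoxy or amine group at this place would test that. From the compounds shown here alone, it also remains open whether the same step would appear with chloro in place of bromo on the ring.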